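Nitro on the pendant phenyl of the cyanopyridone series

The source may hold more compounds than are shown below. What is called first, only, known or untested is meant among the compounds shown, and "the series" means these compounds.

Compound 1 `Cc1cc(O)c(C(C)C)cc1-c1cc(-c2ccccc2)c(C#N)c(=O)[nH]1` carries an unsubstituted phenyl group on the shared core. In a functional assay for inhibition, tested at 80 ug/mL (on this read-out higher numbers stand for a stronger effect at the one concentration tested and lower numbers for a weaker effect), compound 1 gives 58%, which places it second highest among the three measured compounds; the nearest is compound 3 and the furthest compound 2. Compound 2 `COc1ccc(-c2cc(-c3cc(C(C)C)c(O)cc3C)[nH]c(=O)c2C#N)cc1` gives 47.5% in this assay and compound 3 `Cc1cc(O)c(C(C)C)cc1-c1cc(-c2ccc(N(C)C)cc2)c(C#N)c(=O)[nH]1` gives 66.5%.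

Compound 4 `Cc1cc(O)c(C(C)C)cc1-c1cc(-c2ccccc2[N+](=O)[O-])c(C#N)c(=O)[nH]1` differs from compound 1 by one change: nitro in place of hydrogen on an aromatic carbon.

Going by the values given here, two measured steps bear on a substituent entering the phenyl group of compound 1. The step of a number 10.5 percentage points lower from compound 1 to compound 2 (beyond the scatter) was beyond the scatter, while the step of a number 8.5 percentage points higher from compound 1 to compound 3 (within the scatter) stayed within it. Between the two substituted compounds the step of a number 19 percentage points higher from compound 2 to compound 3 (beyond the scatter) was beyond the scatter. Among the compounds with values here, no nitro analogue has been measured, and no measured compound carries a group at the place where the nitro group enters, so the direction for compound 4 cannot be read from these steps. The two substituent steps point in opposite directions and are modest in size, so a step within the scatter is expected in this assay, with the range allowing a modest fall or rise.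

For compound 4 the expected value in this assay is 55%, between 36% and 72%, meaning an estimated step of a number 3 percentage points lower from compound 1 to compound 4 (within the scatter).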

Compound 4, a percentage reported as inhibition, at one concentration (the size of the read-out at that concentration, not a potency): 35%
Compound 4: middle estimate off by 20 percentage points, on the high side; measured number outside the range, below it.
By their numbers in this assay, from the lowest: compound 4; then compound 2; then compounds 1 and 3 (each within the scatter of the next).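

In this assay the change from phenyl to 2-nitrophenyl, with nitro ortho to a large group, gives a number 23 percentage points lower from compound 1 to compound 4 (beyond the scatter), a clear loss from a single substituent entering the phenyl group of compound 1. Going by these compounds alone, the loss also holds against both substituted compounds, with a number 12.5 percentage points lower from compound 2 to compound 4 (beyond the scatter) and a number 31.5 percentage points lower from compound 3 to compound 4 (beyond the scatter), which leaves compound 4 the weakest of the four at the one concentration tested and shows that the substituted phenyl on the shared core can take this read-out further down than the earlier steps did. Nothing available accounts for this fall.

The 2-nitrophenyl group differs from 4-methoxyphenyl and 4-(dimethylamino)phenyl in both the group and its place, so the compounds shown leave open whether the loss follows nitro itself or the place it occupies. A 4-nitrophenyl analogue would bear on the first question, and a 2-aminophenyl or 2-methoxyphenyl analogue on the second.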